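A few compounds are considered here, and "the series" means these few. Any claim that something is new, unique, unknown or untested is made for them only; others in the source may bear on it.

Compound 1 `COc1cc(NS(=O)(=O)c2ccc(N3CCNC3=O)cc2)cc(OC)c1OC` gives 19 nM in a functional assay on K562 cells (Homo sapiens) for antiproliferative activity, read by sulforhodamine B assay, with a stated time of 48 h; a lower number here means a stronger inhibitor, a higher number a weaker inhibitor.
Compound 2 `COc1cccc(NS(=O)(=O)c2ccc(N3CCNC3=O)cc2)c1` gives 230 nM in this assay.
Compound 3 `Cc1cccc(NS(=O)(=O)c2ccc(N3CCNC3=O)cc2)c1` gives 200 nM in this assay.

Compound 2 has the highest number of the three. Compound 3 sits within the scatter of it, while compound 1, with 19 nM, lies well beyond the scatter.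

Compound 4 `O=C1NCCN1c1ccc(S(=O)(=O)Nc2cccc(Cl)c2)cc1` differs from compound 2 in one place: chloro in place of methoxy on an aromatic carbon. Within the data shown here, the one measured step that speaks to this change is a 1.2-fold lower number from compound 2 to compound 3 (0.06 log units; within the scatter), which also replaced this methoxy and stayed within the scatter. On that basis the step to compound 4 is expected to be small, a 1.2-fold lower number from compound 2 to compound 4 (0.06 log units; within the scatter), with no direction beyond the scatter. Compound 4 is therefore estimated at 200 nM in this assay, with a range from 80 nM to 500 nM.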

Compound 4, half-maximal inhibitory concentration: 69 nM
Compound 4: middle estimate off by 2.9-fold (0.46 log units), on the high side; the whole stated range lies above it.
By their numbers in this assay, from the lowest: compound 1; then compound 4; then compounds 3 and 2 (each within the scatter of the next).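

At this place on the ring, the group does matter: methoxy and methyl stood within the scatter of each other, whereas chloro brings a 3.3-fold lower number from compound 2 to compound 4 (0.52 log units; beyond the scatter) and a 2.9-fold lower number from compound 3 to compound 4 (0.46 log units; beyond the scatter) in this assay. So the earlier pair had hidden a real difference among small groups here. Nothing measured on these compounds explains why chloro differs from the other two groups.

On these data alone, whether fluoro, bromo or an amine at this place would match chloro stays open. So does whether the chloro step would carry over to the core of compound 1, which has further methoxy groups.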